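The source may hold more compounds than are shown below. What is called first, only, known or untested is meant among the compounds shown, and "the series" means these compounds.

Among the measured compounds shown here, in a functional assay on HeLa cells (Homo sapiens) for antiproliferative activity, read by MTT assay, with a stated time of 48 h (a higher number here means a weaker inhibitor, a lower number a stronger inhibitor), compound 2 (`Cc1ccc(-c2nc(NC(=O)c3ccccc3)c3cc(Cl)ccc3n2)cc1`) gives 16.2 ug/mL, the highest of the three numbers so far. Compound 1 (`Cc1ccc(-c2nc3ccc(Cl)cc3c(=S)[nH]2)cc1`) gives 4.57 ug/mL, and compound 3 (`Cc1ccc(-c2nc(NOC(=O)c3ccccc3)c3cc(Cl)ccc3n2)cc1`) gives 5.18 ug/mL. Compound 4 (`Cc1ccc(-c2nc(SCCO)c3cc(Cl)ccc3n2)cc1`) has not been measured and differs from compound 2 by (2-hydroxyethyl)sulfanyl in place of benzamido on an aromatic carbon. For the measured compounds named here, only one measured step bears on this place, a 3.1-fold lower number from compound 2 to compound 3 (0.50 log units; beyond the scatter), which is modest and keeps the benzoyl part, so it is a loose guide. Compound 1, which also lacks benzamido, gives 4.57 ug/mL. Expected in this assay is a 2.0-fold lower number from compound 2 to compound 4 (0.31 log units; beyond the scatter), a modest step towards a lower number. For compound 4 the estimated value is 8 ug/mL, with an expected range of 3 ug/mL to 22 ug/mL.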

Compound 4, half-maximal inhibitory concentration: 9.25 ug/mL
Compound 4: the middle estimate sits 1.2-fold (0.06 log units) below what was measured; low and high end bracket the measured number.
By their numbers in this assay, from the lowest: compounds 1, 3, 4 and 2 (each within the scatter of the next, the first and the last beyond it).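

In this assay there is a 1.8-fold lower number from compound 2 to compound 4 (0.24 log units; within the scatter) when (2-hydroxyethyl)sulfanyl replaces benzamido on the aromatic carbon next to the ring nitrogen. At this position, then, a group with no ring gives a number that cannot be told apart from that of benzamido, so the six-membered aromatic ring of benzamido is not needed to hold the number in this range. No measurement on hand gives a reason for this. Going by these compounds, what an amine, a carboxylic acid or a longer chain would give in this place stays open, and so does what the hydroxyl contributes to compound 4.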